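This account rests on a few compounds, and the source may have more. Where it says the series, first, only, none or still open, it means among the compounds named here.

Four compounds share one core and differ only in a single chain: compound 1 `CCn1c(N)c(-c2nc3ccccc3[nH]2)c2nc(C#N)c(C#N)nc21`, compound 2 `CCCn1c(N)c(-c2nc3ccccc3[nH]2)c2nc(C#N)c(C#N)nc21`, compound 3 `CCN(CC)CCCn1c(N)c(-c2nc3ccccc3[nH]2)c2nc(C#N)c(C#N)nc21` and the unmeasured compound 4 `CCN(CC)CCCCn1c(N)c(-c2nc3ccccc3[nH]2)c2nc(C#N)c(C#N)nc21`. In a functional assay on HL-60 cells (Homo sapiens) for antiproliferative activity, read by MTT assay, with a stated time of 48 h (on this read-out higher numbers stand for weaker inhibition and lower numbers for stronger inhibition), compound 1 gives > 50000 nM, which is a limit and not a number. Compound 2 gives 45200 nM. Compound 3 gives > 730 nM, which is also a limit, so its standing is bounded on one side only.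

The change to compound 4 is (diethylamino)methyl in place of diethylamino on a saturated chain carbon, three bonds along the chain from an aromatic nitrogen, which turns 3-(diethylamino)propyl into 4-(diethylamino)butyl.

The closest measured lengthening is an at least 1.1-fold lower number from compound 1 to compound 2 (0.04 log units; that floor lies within the scatter). The other two steps are a step that the two limits leave unreadable from compound 1 to compound 3 and a step that the limit leaves unreadable from compound 2 to compound 3. None of these gives the size of a lengthening in a chain that ends in diethylamino, so no large step is expected in this assay, and the direction remains uncertain.

The estimate for compound 4 is 4000 nM, with an expected range from 700 nM to 30000 nM. This estimate means a step that the limit leaves unreadable from compound 3 to compound 4.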

Compound 4, half-maximal inhibitory concentration: 460 nM
For compound 4 the middle estimate is 8.7-fold (0.94 log units) above the measured one; the measured number lies below the stated range.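

In this assay, among the compounds shown here, compound 4 gives the first exact value for a chain ending in diethylamino, and the 4-(diethylamino)butyl chain stands well clear of the plain alkyl chains, with a 98-fold lower number from compound 2 to compound 4 (1.99 log units; beyond the scatter) and an at least 100-fold lower number from compound 1 to compound 4 (2.03 log units; beyond the scatter). On these data alone, the lengthening from 3-(diethylamino)propyl to 4-(diethylamino)butyl can be read only as an at least 1.5-fold lower number from compound 3 to compound 4 (0.20 log units; that floor lies within the scatter), so the true size of this step remains unknown. The value of compound 3 is only bounded on one side: the limit of > 730 nM in this assay, at which 1 of the 4 values shown sits.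

The compounds shown leave open how activity would change with a longer chain, such as 5-(diethylamino)pentyl, once exact values are available on both sides of each step. They also leave open whether a piperidine or a morpholine at the chain end would match diethylamino.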